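The source may report more compounds than this note shows. Statements on the series, on what has been measured and on what is new or still open speak of the compounds shown alone.

Measured so far:
compound 1 `COc1ccccc1S(=O)(=O)/C=C/c1cccnc1Cl`, 77%;
compound 2 `COc1ccccc1S(=O)(=O)/C=C/c1ccc(Cl)nc1Cl`, 18%;
compound 3 `COc1cccc(S(=O)(=O)/C=C/c2cccnc2)c1`, 75%.

In an ADME assay on microsomes from liver (Homo sapiens) for metabolic stability, read by LC-MS, using NADPH, with stated times of 5 min and 30 min, tested at 1 uM (a higher number here means that more of the compound is left, a lower number that less of the compound is left), compound 1 gives 77%. The change chloro in place of hydrogen on an aromatic carbon gave a number 59 percentage points lower from compound 1 to compound 2 (beyond the scatter). The difference between the core of compound 1 and the core of compound 3 is not broken down here. Compound 4 `COc1cccc(S(=O)(=O)/C=C/c2cccnc2Cl)c1` arises from compound 3 by chloro in place of hydrogen on an aromatic carbon, the same kind of change, but the place differs: in compound 2 the chloro sits meta to a chloro group and para to a large group, in compound 4 ortho to a large group. Compound 1 already carries a chloro in such a place and gives 77%, so the step is expected to be small, a number 7 percentage points lower from compound 3 to compound 4 (within the scatter). Compound 4 is estimated at 68%.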

Compound 4, percent of the compound remaining: 29%
For compound 4 the middle estimate is 39 percentage points above the measured one; measured number outside the range, below it.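

In this assay, chloro in place of hydrogen on an aromatic carbon gave a number 46 percentage points lower from compound 3 to compound 4 (beyond the scatter). Set beside the earlier step, the change carried over from one core to the other at a similar size: the same change on two cores in this assay, a number 59 percentage points lower (beyond the scatter) from compound 1 to compound 2 and a number 46 percentage points lower (beyond the scatter) from compound 3 to compound 4, 13 percentage points apart, within the scatter of two such steps. Within the data shown here, this is only one pair of steps, with the chloro in a different place in each, so it does not show that the change would act alike on other cores, nor why less of the compound is left.

The compounds shown leave open whether another group on the same aromatic carbon, such as fluoro, methyl or an amine, would lower the number as far. They also leave open whether a carboxylic acid elsewhere on the core would alter the size of the chloro step.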